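Two Aryl Swaps on One Core: Expected Growth Inhibition

This account rests on a few compounds, and the source may have more. Where it says the series, first, only, none or still open, it means among the compounds named here.

Three compounds were measured in a functional assay on DU-145 cells (Homo sapiens) for inhibition, read by trypan blue exclusion, with a stated time of 96 h; a higher number here means a weaker inhibitor of growth, a lower number a stronger inhibitor of growth:

Compound 1, `Cc1ccsc1/C=C(/SCc1ccc(Cl)cc1)C(=O)c1ccc(Cl)cc1`: 50000 nM
Compound 2, `Cc1ccc(C)c(/C=C(/SCc2ccc(Cl)cc2)C(=O)c2ccc(Cl)cc2)c1`: 10000 nM
Compound 3, `Cc1ccc(C)c(/C=C(/SCc2ccc(F)cc2)C(=O)c2ccc(Br)cc2)c1`: 1000 nM

Compounds 1 and 2 share a core and differ in one place: 3-methylthiophen-2-yl in place of 2,5-dimethylphenyl on a double-bonded chain carbon bound to a double-bonded chain carbon. This change produced a 5.0-fold higher number from compound 2 to compound 1 (0.70 log units; beyond the scatter), so compound 1 is the weaker growth inhibitor of the pair.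

Compound 3 stands apart from compound 2 in more than one place, and how its core differs from that of compound 2 is not broken down here. In this assay compound 3 gives the lowest number of the three, a step beyond the scatter from compound 2 and a larger one from compound 1.

Compound 4, `Cc1ccsc1/C=C(/SCc1ccc(F)cc1)C(=O)c1ccc(Br)cc1`, is not yet measured. It is related to compound 3 by 3-methylthiophen-2-yl in place of 2,5-dimethylphenyl on a double-bonded chain carbon bound to a double-bonded chain carbon. The place of the change is the same, word for word, as the place of the change from compound 2 to compound 1, so this is the same change made on the core of compound 3.

Among the measured compounds shown here, the expectation for compound 4 therefore rests on the one earlier instance of this change. From compound 3 to compound 4 a step of a 5.0-fold higher number from compound 3 to compound 4 (0.70 log units; beyond the scatter) is expected, because the earlier step was a 5.0-fold higher number from compound 2 to compound 1 (0.70 log units; beyond the scatter). With that step applied to the value of compound 3, compound 4 is estimated at 5000 nM, with a likely span from 1500 nM to 16000 nM.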

Compound 4, concentration for 50% growth inhibition: 50000 nM
Estimate against measurement, compound 4: 10-fold (1.00 log units) below; measured number above the stated range.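

In this assay, the change of 2,5-dimethylphenyl to 3-methylthiophen-2-yl on the core of compound 3 gave a 50-fold higher number from compound 3 to compound 4 (1.70 log units; beyond the scatter), so the compound carrying 3-methylthiophen-2-yl is again the weaker growth inhibitor of its pair. The direction of the change therefore held on both cores in this small set, but its size did not carry over from one core to the other: the same change on two cores in this assay, a 5.0-fold higher number (0.70 log units; beyond the scatter) from compound 2 to compound 1 and a 50-fold higher number (1.70 log units; beyond the scatter) from compound 3 to compound 4, 10-fold (1.00 log units) apart, beyond the scatter of two such steps

This does not show why the size differs, since the cores of compound 2 and compound 3 differ in more than one place and these two pairs cannot tell which of those differences matters, or whether they act together; with only two instances, it also gives no general rule for predicting the size of this step on a further core. The compounds shown leave open how the step would behave on cores carrying a methoxy group or a nitrile in place of the halogens, and on cores that differ from one another in a single place. They also leave open whether an unsubstituted thiophene or a pyridine ring in the same place would follow the 3-methylthiophen-2-yl compounds.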